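Chain length on a shared core with no measurable effect

The source may report more compounds than this note shows. Statements on the series, on what has been measured and on what is new or still open speak of the compounds shown alone.

Three compounds share one core and differ only in the chain attached to it and in a group on an outer ring. Compound 1 `CCCCc1cc2ccccc2nc1-c1cc(-c2ccc(C)cc2)no1`, compound 2 `CCCCCc1cc2ccccc2nc1-c1cc(-c2ccc(C)cc2)no1` and compound 3 `CCc1cc2ccccc2nc1-c1cc(-c2ccc(C(F)(F)F)cc2)no1` were all tested in a functional assay on MDA-MB-231 cells (Homo sapiens) for inhibition, read by MTT assay, with a stated time of 24 h; on this read-out lower numbers stand for stronger inhibition and higher numbers for weaker inhibition. In this assay compound 1 gives only a limit of the assay, > 100000 nM. Compound 2 likewise gives only a limit, > 100000 nM. Compound 3 also gives only a limit, > 100000 nM. The change from compound 1 to compound 2 is methyl in place of hydrogen on a saturated chain carbon, four bonds along the chain from an aromatic carbon, and the step it made is a step that the two limits leave unreadable from compound 1 to compound 2. How the core of compound 1 and the core of compound 3 differ is not broken down here.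

Compound 4 `CCCc1cc2ccccc2nc1-c1cc(-c2ccc(C(F)(F)F)cc2)no1` has not yet been measured. It differs from compound 3 by methyl in place of hydrogen on a saturated chain carbon, two bonds along the chain from an aromatic carbon. This is the same kind of change as that from compound 1 to compound 2, but the place differs: in compound 4 the new methyl sits two bonds along the chain from an aromatic carbon, whereas from compound 1 to compound 2 it sits four bonds along the chain from an aromatic carbon. Because (the limit of > 100000 nM in this assay, at which 3 of the 3 values shown sit), the three compounds give no readable step at all, so the effect of lengthening the chain is not known. Given this, compound 4 is expected to show a step that the limit leaves unreadable from compound 3 to compound 4. Compound 4 is therefore estimated at 150000 nM in this assay, with a range from 40000 nM to 600000 nM, and most likely it will again come back as a limit rather than a number.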

Compound 4, half-maximal inhibitory concentration: 36500 nM
Compound 4: the middle estimate sits 4.1-fold (0.61 log units) above what was measured, outside the stated range (below it).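

Within the data shown here, on the core of compound 3, methyl in place of hydrogen on a saturated chain carbon, two bonds along the chain from an aromatic carbon, gives an at least 2.7-fold lower number from compound 3 to compound 4 (0.43 log units; beyond the scatter) in this assay, so the number for compound 4, 36500 nM, is the first real reading in this small set. The same kind of change on the core of compound 1 cannot be read, and that comparison also differs in the place of the new methyl and in the group on the outer ring, so nothing here shows whether the change carries from one core to the other: the limit of > 100000 nM in this assay, at which 3 of the 4 values shown sit. This result is therefore a single readable step on a single core, and it does not establish a general rule that lengthening the chain lowers the number.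

The compounds shown leave open whether a longer chain, such as butyl or pentyl, on the core of compound 3 would lower the number further or return it to the limit. They also leave open whether a propyl chain on the core of compound 1 would give a measurable value, and how an amine or a carboxylic acid in place of the propyl chain of compound 4 would read.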